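The source may report more compounds than this note shows. Statements on the series, on what has been measured and on what is new or still open speak of the compounds shown alone.

In a functional assay on HeLa cells (Homo sapiens) for inhibition, read by sulforhodamine B assay (on this read-out lower numbers stand for stronger inhibition and higher numbers for weaker inhibition), compound 3 (`CCCN(CCC)C1=CC(=O)c2nc3n(c2C1=O)[C@H]1OC[C@@H](O)[C@H]1OC3`) reads > 16000 nM, which is a limit of the assay and not a number. Compound 1 (`O=C1C=C(NC2CCCC2)C(=O)c2c1nc1n2[C@H]2OC[C@@H](O)[C@H]2OC1`) reads > 16000 nM, which is likewise a limit. Compound 2 (`COc1ccccc1NC1=CC(=O)c2nc3n(c2C1=O)[C@H]1OC[C@@H](O)[C@H]1OC3`) gives a number, 2950 nM. Going by the values given here, the series so far shows (the limit of > 16000 nM in this assay, at which 2 of the 3 values shown sit).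

The change under review leads to compound 4 (`O=C1C=C(N2CCCCC2)C(=O)c2c1nc1n2[C@H]2OC[C@@H](O)[C@H]2OC1`): piperidin-1-yl in place of dipropylamino on a double-bonded ring carbon, with piperidin-1-yl in place of dipropylamino on a double-bonded ring carbon. Among the compounds with values here, no measured pair makes this exchange directly. The two readable steps both involve the (2-methoxyphenyl)amino group of compound 2: an at least 5.4-fold lower number from compound 1 to compound 2 (0.73 log units; beyond the scatter) and an at least 5.4-fold higher number from compound 2 to compound 3 (0.73 log units; beyond the scatter). Compound 4 lacks that group, as do compound 1 and compound 3. Between those two, the limits give only a step that the two limits leave unreadable from compound 1 to compound 3. On three compounds this is thin support, but it gives no reason to expect compound 4 to move far from compound 3. In this assay, no step beyond the scatter is therefore expected. The expected step is an at least 1.1-fold lower number from compound 3 to compound 4 (0.05 log units; that floor lies within the scatter), and a report of only a limit is quite possible. For compound 4 the estimated value is 14000 nM, with an expected range from 5000 nM to 32000 nM.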

Compound 4, half-maximal inhibitory concentration: > 16000 nM
Compound 4: only a limit was reported; the forecaster's own chance of this, stated with the estimate: 60%; middle value at least 1.1-fold (0.05 log units) from the limit.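

Piperidin-1-yl on the double-bonded ring carbon does not bring a readable value in this assay: the steps to compound 4 from compound 1 and from compound 3 cannot be read, as both ends of each are limits of the assay and not numbers. The exchange of (2-methoxyphenyl)amino for piperidin-1-yl gives an at least 5.4-fold higher number from compound 2 to compound 4 (0.73 log units; beyond the scatter), a step of the same printed size as an at least 5.4-fold higher number from compound 2 to compound 3 (0.73 log units; beyond the scatter), so a six-membered ring on this carbon reads no differently here from the open dipropylamino group. Compound 2 remains the only compound of the four with a number, while cyclopentylamino, dipropylamino and piperidin-1-yl all end at one boundary: the limit of > 16000 nM in this assay, at which 3 of the 4 values shown sit.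

From the compounds shown here alone, how far compound 1, compound 3 and compound 4 lie past that limit stays unknown, so no order among them can be given. Also open, going by these compounds, is whether the number of compound 2 depends on the aromatic ring or on its methoxy group, and what a plain phenylamino group or a morpholin-4-yl group would read at this carbon.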